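Replacing the Aminophenyl Ether Group with a Thiophene Ring

The source may hold more compounds than are shown below. What is called first, only, known or untested is meant among the compounds shown, and "the series" means these compounds.

Three compounds share one core and differ only in the aromatic group carried on the ether. In an assay on CHO cells for binding affinity to metabotropic glutamate receptor 2 (Rattus norvegicus) (a lower number here means a stronger inhibitor, a higher number a weaker inhibitor), compound 1 `N[C@]1(C(=O)O)[C@H]2[C@@H](C[C@H]1OCc1cccc(-c3ccccc3)c1)[C@]2(F)C(=O)O` gives 9.34 nM, compound 2 `N[C@]1(C(=O)O)[C@H]2[C@@H](C[C@H]1OCc1cccc(Oc3ccccc3)c1)[C@]2(F)C(=O)O` gives 7.15 nM, and compound 3 `Nc1cccc(CO[C@@H]2C[C@@H]3[C@H]([C@]2(N)C(=O)O)[C@@]3(F)C(=O)O)c1` gives 15.4 nM, the highest of the three numbers. The step of a 1.6-fold higher number from compound 1 to compound 3 (0.22 log units; within the scatter) lies within the scatter, while a 2.2-fold higher number from compound 2 to compound 3 (0.33 log units; beyond the scatter) is modest. Compound 4 `N[C@]1(C(=O)O)[C@H]2[C@@H](C[C@H]1OCc1cccs1)[C@]2(F)C(=O)O` carries thiophen-2-yl in place of 3-aminophenyl on a saturated chain carbon bound to an oxygen on a saturated carbon. Going by the values given here, no measured step swaps the whole aromatic ring; the two steps ending at compound 3 only vary a group on the six-membered aromatic ring of carbon only and move the number little. Compound 4 is therefore expected to change little: a 1.0-fold lower number from compound 3 to compound 4 (0.01 log units; within the scatter). The estimate for compound 4 is 15 nM, ranging from 6 nM to 40 nM.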

Compound 4, inhibition constant: 8.79 nM
Compound 4: the middle estimate sits 1.7-fold (0.23 log units) above what was measured; the measured number falls inside the stated range.
By their numbers in this assay, from the lowest: compounds 2, 4, 1 and 3 (each within the scatter of the next, the first and the last beyond it).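

Replacing the whole ring, thiophen-2-yl in place of 3-aminophenyl, gives a 1.8-fold lower number from compound 3 to compound 4 (0.24 log units; within the scatter) and stays within the scatter. Earlier steps varied only a group on the six-membered aromatic ring of carbon only, whereas this one shows that a five-membered aromatic ring with 1 hetero atom can stand at this position, without the hydrogen-bond donor of 3-aminophenyl, and leave the number within the scatter. Nothing available explains this result. The compounds shown leave open how a furan or pyridine ring would read here, and whether a phenyl, phenoxy or amine group on the thiophene would move the number.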